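The source may report more compounds than this note shows. Statements on the series, on what has been measured and on what is new or still open speak of the compounds shown alone.

Compound 1, `CCOCCn1c(N2CCN(C)CC2)nc2ccccc21`, gives 10 nM in a functional assay on ileum for inhibition of histamine H1 receptor (Cavia porcellus); on this read-out higher numbers stand for weaker inhibition and lower numbers for stronger inhibition.
Compound 2, `CC(C)CCn1c(N2CCN(C)CC2)nc2ccccc21`, gives 1400 nM in this assay.
Compound 3, `COCCCn1c(N2CCN(C)CC2)nc2ccccc21`, gives 860 nM in this assay.

Among these three numbers compound 3 holds the second highest. Its nearest neighbour is compound 2, separated from it only by a 1.6-fold lower number from compound 2 to compound 3 (0.21 log units; within the scatter); the furthest is compound 1, and that distance is an 86-fold higher number from compound 1 to compound 3 (1.93 log units; beyond the scatter).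

Compound 4, `CCCCCCCCCCn1c(N2CCN(C)CC2)nc2ccccc21`, has not yet been measured. Compared with compound 3 it shows (heptyl in place of methoxy on a saturated chain carbon, three bonds along the chain from an aromatic nitrogen). Going by the values given here, two measured steps bear on this. The step of an 86-fold higher number from compound 1 to compound 3 (1.93 log units; beyond the scatter) and the step of a 140-fold higher number from compound 1 to compound 2 (2.15 log units; beyond the scatter) both show that moving from the ethoxy of compound 1 to a longer or branched chain raises the number strongly. Between the two longer chains, the step of a 1.6-fold lower number from compound 2 to compound 3 (0.21 log units; within the scatter) shows no clear preference for keeping or dropping the hydrogen-bond acceptor. Compound 4 carries a long chain with no hydrogen-bond acceptor, so in this assay a step upward that is at most small, or none beyond the scatter, is expected. The expected step for compound 4 is a 2.3-fold higher number from compound 3 to compound 4 (0.37 log units; beyond the scatter). Compound 4 is therefore estimated at 2000 nM, with a range from 500 nM to 8000 nM.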

Compound 4, half-maximal inhibitory concentration: 4200 nM
The estimate for compound 4 lay 2.1-fold (0.32 log units) below the measured number, and the stated range covers the measured number.
By their numbers in this assay, from the lowest: compound 1; then compounds 3 and 2 (each within the scatter of the next); then compound 4.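

In this assay, the longest chain in the set brings a 4.9-fold higher number from compound 3 to compound 4 (0.69 log units; beyond the scatter) with heptyl in place of methoxy, and a 3.0-fold higher number from compound 2 to compound 4 (0.48 log units; beyond the scatter) with octyl in place of isopropyl. So the number at this position can still climb beyond the similar values of compounds 2 and 3, and the change of octyl in place of ethoxy gives the largest step in the set, a 420-fold higher number from compound 1 to compound 4 (2.62 log units; beyond the scatter). Nothing measured here explains these differences.

Going by these compounds, whether the low number of compound 1 is tied to the ethoxy group itself remains open, as a hydroxyl or an amine at this position could test that. On these data alone, it is also open how the number changes for chains of intermediate length, such as pentyl or hexyl.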